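The source may hold more compounds than are shown below. What is called first, only, known or untested is meant among the compounds shown, and "the series" means these compounds.

Compound 1 `CCOC(=O)CO/N=C(/c1ccc(OC)c(OC)c1OC)c1cccc2ccccc12` carries an ethoxycarbonyl group on the chain that hangs from the oxime oxygen of the shared core, and in a functional assay on MDA-MB-231 cells (Homo sapiens) for inhibition, read by sulforhodamine B assay, with a stated time of 48 h (a lower number here means a stronger inhibitor, a higher number a weaker inhibitor), compound 1 gives 16400 nM. Compound 2 `CCOC(=O)/C=C/CO/N=C(/c1ccc(OC)c(OC)c1OC)c1cccc2ccccc12` lengthens that chain by one ethenyl unit. In this assay compound 2 reaches only a limit, > 20000 nM, so its true number is not known. The step of an at least 1.2-fold higher number from compound 1 to compound 2 (0.08 log units; that floor lies within the scatter) therefore shows little, because it rests on the limit of > 20000 nM in this assay, at which 1 of the 2 values shown sits, and sits at a floor that falls inside the usual scatter of repeats. Compound 3 `COc1ccc(/C(=N/OC(C)=O)c2cccc3ccccc23)c(OC)c1OC` changes the same oxygen once more: acetyl in place of 3-(ethoxycarbonyl)prop-2-en-1-yl on an oxygen. Going by the values given here, only one measured step touches this oxygen, and it was small, so no direction can be taken from it with confidence; both measured compounds are weak inhibitors in this assay, and compound 3 is expected to stay in that weak range, with the step of an at least 1.3-fold lower number from compound 2 to compound 3 (0.12 log units; that floor lies within the scatter) counted as an estimate. In this assay compound 3 is estimated at 15000 nM, within a range from 5000 nM to 40000 nM.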

Compound 3, half-maximal inhibitory concentration: 17000 nM
The estimate for compound 3 lay 1.1-fold (0.05 log units) below the measured number, within the range that was stated.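

Going by these compounds alone, on the oxygen whose other neighbour is the double-bonded nitrogen, acetyl in place of (ethoxycarbonyl)methyl gives the first step at this position that joins two true numbers: a 1.0-fold higher number from compound 1 to compound 3 (0.02 log units; within the scatter). In this assay, these two quite different groups therefore cannot be told apart, and the weak inhibition seen so far does not depend on which of the two is present. Compound 2 stands at a limit rather than a number, so its steps to the other compounds cannot be read. That holds for the new step, an at least 1.1-fold lower number from compound 2 to compound 3 (0.07 log units; that floor lies within the scatter), which gives no direction: the limit of > 20000 nM in this assay, at which 1 of the 3 values shown sits.

Going by these compounds, it remains open whether any group on this oxygen can move the number beyond the usual scatter, for instance an amine or a carboxylic acid at the end of a longer chain. On these data alone, how far compound 2 really lies past its limit also stays unknown, so the 3-(ethoxycarbonyl)prop-2-en-1-yl group cannot yet be ranked against acetyl or (ethoxycarbonyl)methyl.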